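A few compounds are considered here, and "the series" means these few. Any claim that something is new, unique, unknown or untested is made for them only; others in the source may bear on it.

For the measured compounds named here, compound 2 `CN(C)CCn1cnnc1-c1cc(Oc2ccc(NC(=O)N/N=C/c3ccc(O)c(F)c3)cc2F)ccn1` stands as the higher of the two numbers so far: in a functional assay on A549 cells (Homo sapiens) for cytotoxicity, read by MTT assay, with a stated time of 72 h (a lower number here means a stronger inhibitor, a higher number a weaker inhibitor), compound 2 gives 13400 nM, while compound 1 `CN(C)CCn1cnnc1-c1cc(Oc2ccc(NC(=O)N/N=C/c3ccccc3O[N+](=O)[O-])cc2F)ccn1` gives 1200 nM. Going by the values given here, the single measured step, an 11-fold higher number from compound 1 to compound 2 (1.05 log units; beyond the scatter), already varies the aryl group on the carbon with a double bond to nitrogen. Compound 3 `CN(C)CCn1cnnc1-c1cc(Oc2ccc(NC(=O)N/N=C/c3ccc(O)cc3O)cc2F)ccn1` varies that same group once more: 2,4-dihydroxyphenyl in place of 3-fluoro-4-hydroxyphenyl on a carbon with a double bond to nitrogen. Among the compounds with values here, only that one step bears on this position, and it was large; it shows that the aryl group on this carbon moves the number a good deal, but compound 1 and compound 2 carry quite different groups, so it gives no direction for this particular exchange. A step smaller than the measured one is therefore expected, with the direction uncertain. As a working estimate compound 3 is expected at 7000 nM in this assay, within 1500 nM to 30000 nM. That estimate would mean a 1.9-fold lower number from compound 2 to compound 3 (0.28 log units; within the scatter).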

Compound 3, half-maximal inhibitory concentration: 12700 nM
For compound 3 the middle estimate is 1.8-fold (0.26 log units) below the measured one; the range from low to high includes it.
By their numbers in this assay, from the lowest: compound 1; then compounds 3 and 2 (each within the scatter of the next).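

In this assay, 2,4-dihydroxyphenyl and 3-fluoro-4-hydroxyphenyl on a carbon with a double bond to nitrogen cannot be told apart (a 1.1-fold lower number from compound 2 to compound 3 (0.02 log units; within the scatter)). The exchange away from 2-(nitrooxy)phenyl now gives a large step with a second entering group (an 11-fold higher number from compound 1 to compound 3 (1.02 log units; beyond the scatter)), so among these three compounds the large step goes with the loss of 2-(nitrooxy)phenyl and not with one particular replacement. No supporting data bear on why the number shifts at this position.

Still open, as far as these compounds go, is whether a plain phenyl, a methoxyphenyl or an aminophenyl on this carbon would fall with compound 1 or with compound 2 and compound 3. The compounds shown also leave open whether the nitrooxy group itself accounts for the separation of compound 1 from the other two.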